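A Thiophene in Place of a Bromofuran

The compounds below may be only part of what the source reports. "The series", "measured", "known", "first", "only" and "open" are said of these compounds alone.

In a functional assay on the whole organism with Mus musculus as the target (on this read-out higher numbers stand for an effect only at larger amounts of compound and lower numbers for an effect already at smaller amounts), the evidence so far is thin. Among the compounds with values here, compound 2 (`CN(C)C(=O)Cn1c(-c2ccc(Br)o2)nc2cccnc21`) gives 100 mg/kg as the only single number available. Compound 1 (`CN(C)C(=O)Cn1c(-c2cccc(Cl)c2)nc2cccnc21`) is known only through limits of the assay, recorded as > 56.2 mg/kg; < 100 mg/kg (2 entries) and not as one number. The step followed here leads to compound 3 (`CN(C)C(=O)Cn1c(-c2ccsc2)nc2cccnc21`) which carries thiophen-3-yl in place of 5-bromofuran-2-yl on an aromatic carbon of the shared core (thiophen-3-yl in place of 5-bromofuran-2-yl on an aromatic carbon). No measured exchange in the series shows what such a change does in this assay so the expectation stays modest, with no shift beyond the usual scatter in either direction. The expected size of the change is no change at the digits printed from compound 2 to compound 3 (within the scatter) and no more. Compound 3 is estimated at 100 mg/kg with an expected range from 40 mg/kg to 250 mg/kg still to be tested.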

Compound 3, dose for half-maximal effect: 38 mg/kg
Compound 3: middle estimate off by 2.6-fold (0.42 log units), on the high side; the measured number lies below the stated range.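

In this assay the series now has its first readable step at this position, the aromatic carbon between two ring nitrogen atoms: a 2.6-fold lower number from compound 2 to compound 3 (0.42 log units; beyond the scatter). A lower number here means an effect already at smaller amounts, so this position does respond to an exchange of one five-membered aromatic ring with one hetero atom for another. Nothing measured in the series bears on why the number moves, and the exchange alters several features at once, since bromine leaves and sulfur replaces oxygen.

The compounds shown leave open whether the bromine, the ring hetero atom or the point of attachment carries the step, and how a thiophen-2-yl or an unsubstituted furan-2-yl group would read at this position. Also open, from the compounds shown here alone, is what happens when the (dimethylcarbamoyl)methyl group, the same throughout, gives way to a carboxylic acid.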